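Sulfamate series: swapping piperidinyl for a pyridinylmethyl amine

The source may hold more compounds than are shown below. What is called first, only, known or untested is meant among the compounds shown, and "the series" means these compounds.

Measured compounds:
compound 1, `CN(C)CCN(CCN(C)C)c1ccc(C(=O)N2CCc3ccc(OS(N)(=O)=O)cc3C2)cc1`, gives 3.8%;
compound 2, `CCN(Cc1ccccn1)c1ccc(C(=O)N2CCc3ccc(OS(N)(=O)=O)cc3C2)cc1`, gives 42.5%;
compound 3, `NS(=O)(=O)Oc1ccc2c(c1)CN(C(=O)c1ccc(N3CCCCC3)cc1)CC2`, gives 11.5%.

All three share one core and differ only in the amine attached to the benzamide ring. In an assay on HEK293 cells for inhibition of Steryl-sulfatase (Homo sapiens), tested at 0.1 uM (on this read-out higher numbers stand for a stronger effect at the one concentration tested and lower numbers for a weaker effect), compound 3 sits second of the three numbers: it is close to compound 1, and the gap a number 7.7 percentage points higher from compound 1 to compound 3 (within the scatter) is within the scatter, while it lies well under compound 2, as a number 31 percentage points lower from compound 2 to compound 3 (beyond the scatter) shows.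

The unmeasured compound 4, `CCN(Cc1ccncc1)c1ccc(C(=O)N2CCc3ccc(OS(N)(=O)=O)cc3C2)cc1`, carries a new amine: ethyl((pyridin-4-yl)methyl)amino in place of piperidin-1-yl on an aromatic carbon.

Among the measured compounds shown here, two measured steps bear on this. The step of a number 38.7 percentage points higher from compound 1 to compound 2 (beyond the scatter) and the step of a number 31 percentage points lower from compound 2 to compound 3 (beyond the scatter) both show that the ethyl((pyridin-2-yl)methyl)amino group of compound 2 stands far above both the piperidin-1-yl group and the bis(2-(dimethylamino)ethyl)amino group. For the measured compounds named here, the group entering in compound 4 resembles the one in compound 2, so a sizeable rise in this assay is expected, though the ring joins differently and that is untested here. Compound 4 is therefore estimated at 30%, with a likely range from 10% to 52%, which corresponds to an expected step of a number 18.5 percentage points higher from compound 3 to compound 4 (beyond the scatter).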

Compound 4, a percentage reported as inhibition, at one concentration (the size of the read-out at that concentration, not a potency): 47%
Beside the measured number, compound 4's estimate is 17 percentage points below it, and the stated range covers the measured number.
By their numbers in this assay, from the lowest: compounds 1 and 3 (each within the scatter of the next); then compounds 2 and 4 (each within the scatter of the next).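

In this assay, the position of the ring nitrogen in the pyridine now has a direct test, and the step from pyridin-2-yl to pyridin-4-yl, a number 4.5 percentage points higher from compound 2 to compound 4 (within the scatter), stays within the scatter, so this read-out does not separate the two amines. The high level is therefore not confined to the pyridin-2-yl group: the ethyl((pyridin-4-yl)methyl)amino group also stands clear of the piperidin-1-yl group, with a number 35.5 percentage points higher from compound 3 to compound 4 (beyond the scatter), and of the bis(2-(dimethylamino)ethyl)amino group, with a number 43.2 percentage points higher from compound 1 to compound 4 (beyond the scatter), so among these four compounds the two ethyl(pyridinylmethyl)amino groups form the upper pair. No measurement here explains why these amines separate in this way.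

Still open, as far as these compounds go, is whether the pyridine nitrogen matters at all, a question that a plain phenyl ring in place of the pyridine would address, and how a pyridin-3-yl group would compare with the two pyridine attachments seen here. Also open, from the compounds shown here alone, is what part the ethyl group plays, which a methyl group or a longer propyl chain on the same nitrogen would help to show.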